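The compounds below may be only part of what the source reports. "The series", "measured", "known", "first", "only" and "open" are said of these compounds alone.

Compound 1 `CCCCCCc1cccc(N2CCNCC2)n1`: in a functional assay on the whole organism with Mus musculus as the target, in the maximal electroshock model, with a stated time of 120 min (a lower number here means that less compound is needed, a higher number that more compound is needed for the effect), compound 1 gives 10 mg/kg.
Compound 2 `CC(C)(C)c1cccc(N2CCNCC2)n1`: in this assay compound 2 gives > 300 mg/kg, which is a limit of the assay and not a number.
Compound 3 `CCCCc1cccc(N2CCNCC2)n1`: in this assay compound 3 gives 30 mg/kg.

Among the two numbers measured, compound 3 stands highest; its nearest neighbour is compound 1, and the step of a 3.0-fold higher number from compound 1 to compound 3 (0.48 log units; beyond the scatter) lies beyond the scatter. Compound 2 is known only as a limit, (the limit of > 300 mg/kg in this assay, at which 1 of the 3 values shown sits).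

The step to compound 4 `CCCCCc1cccc(N2CCNCC2)n1` is methyl in place of hydrogen on a saturated chain carbon, four bonds along the chain from an aromatic carbon. Of the measured steps, only a 3.0-fold higher number from compound 1 to compound 3 (0.48 log units; beyond the scatter) bears directly on this change, since it too alters the length of the straight chain at the same place, in the opposite direction. The two steps that involve compound 2, an at least 30-fold higher number from compound 1 to compound 2 (1.47 log units; beyond the scatter) and an at least 10-fold lower number from compound 2 to compound 3 (1.00 log units; beyond the scatter), concern tert-butyl against a straight chain and say nothing about lengthening that chain by one carbon.

Because a 3.0-fold higher number from compound 1 to compound 3 (0.48 log units; beyond the scatter) corresponds to two carbons removed, a single carbon added to compound 3 is expected to lower the number modestly, by less than that step. Compound 4 is therefore expected to give 17 mg/kg, within 8 mg/kg to 40 mg/kg, an expected step of a 1.8-fold lower number from compound 3 to compound 4 (0.25 log units; within the scatter).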

Compound 4, minimum effective dose: 10 mg/kg
Compound 4: middle estimate off by 1.7-fold (0.23 log units), on the high side; low and high end bracket the measured number.
By their numbers in this assay, from the lowest: compounds 1 and 4 (each within the scatter of the next); then compound 3. At a limit, above all of these: compound 2.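

In this assay, the one carbon that turns the butyl chain of compound 3 into the pentyl chain of compound 4 is a step beyond the scatter in its own right (a 3.0-fold lower number from compound 3 to compound 4 (0.48 log units; beyond the scatter)), and it is as large at the digits printed as the step across the two carbons separating compound 1 and compound 3 (a 3.0-fold higher number from compound 1 to compound 3 (0.48 log units; beyond the scatter)). The next carbon along the chain adds nothing that can be read (no change at the digits printed from compound 1 to compound 4 (within the scatter)), so among compounds 3, 4 and 1 the whole change with chain length lies in the move from butyl to pentyl, and none of these three goes against that. The pentyl chain also stands far from the tert-butyl group (an at least 30-fold lower number from compound 2 to compound 4 (1.47 log units; beyond the scatter)), though that step rests on a value of compound 2 that is a limit of the assay and not a number: the limit of > 300 mg/kg in this assay, at which 1 of the 4 values shown sits.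

The compounds shown leave open whether a longer chain such as heptyl or octyl would hold the number where compound 1 and compound 4 stand or move it. They also leave open how a branched isopentyl chain, a cyclohexyl ring or a terminal hydroxyl group on the chain would compare with the straight pentyl chain.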